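The compounds below may be only part of what the source reports. "The series", "measured", "known", "first", "only" and "open" are said of these compounds alone.

Compound 3 `Nc1ncnn2c([C@@H]3O[C@H](CO)[C@@H](O)[C@H]3O)cc(-c3ccc(Cl)cc3)c12` gives 32600 nM in a functional assay on LN-229 cells (Homo sapiens) for antiproliferative activity, with a stated time of 72 h (on this read-out higher numbers stand for weaker inhibition and lower numbers for stronger inhibition), the second highest number of the three measured here; its nearest neighbour is compound 2 `Nc1ncnn2c([C@@H]3O[C@H](CO)[C@@H](O)[C@H]3O)cc(-c3ccc(F)cc3)c12` with 65600 nM, and far from both stands compound 1 `CCCC#Cc1cc([C@@H]2O[C@H](CO)[C@@H](O)[C@H]2O)n2ncnc(N)c12` with 40 nM. The steps of a 1600-fold higher number from compound 1 to compound 2 (3.21 log units; beyond the scatter) and an 820-fold higher number from compound 1 to compound 3 (2.91 log units; beyond the scatter) show that either aryl group in place of the pent-1-yn-1-yl chain gives a very weak compound, while a 2.0-fold lower number from compound 2 to compound 3 (0.30 log units; within the scatter) shows the halogen swap making no difference beyond the scatter. Compound 4 `Nc1ncnn2c([C@@H]3O[C@H](CO)[C@@H](O)[C@H]3O)cc(-c3ccccc3F)c12` carries the change (2-fluorophenyl in place of 4-chlorophenyl on an aromatic carbon). For the measured compounds named here, the only step that bears on it is the within-scatter halogen swap, so a step of a 1.5-fold higher number from compound 3 to compound 4 (0.19 log units; within the scatter) of no real size is expected. Compound 4 is therefore estimated at 50000 nM in this assay, between 15000 nM and 160000 nM.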

Compound 4, half-maximal inhibitory concentration: > 100000 nM
Compound 4 gave a limit, no number; the forecaster's own chance of this, stated with the estimate: 25%; middle value at least 2.0-fold (0.30 log units) from the limit.
By their numbers in this assay, from the lowest: compound 1; then compounds 3 and 2 (each within the scatter of the next). At a limit, above all of these: compound 4.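

Compound 4 gives only a limit in this assay, not a number: the limit of > 100000 nM in this assay, at which 1 of the 4 values shown sits. The 2-fluorophenyl group separates from 4-chlorophenyl, with an at least 3.0-fold higher number from compound 3 to compound 4 (0.48 log units; beyond the scatter), whereas the halogen swap did not, but an at least 1.5-fold higher number from compound 2 to compound 4 (0.18 log units; that floor lies within the scatter) leaves the comparison of the two fluorophenyl groups unresolved. With an at least 2500-fold higher number from compound 1 to compound 4 (3.39 log units; beyond the scatter), this third aryl group also falls far short of the pent-1-yn-1-yl chain. Going by these compounds, it stays open whether 2-chlorophenyl would behave like 2-fluorophenyl or like 4-chlorophenyl. On these data alone, it also stays open whether a shorter alkyne, a longer alkyne or an amine on this aromatic carbon would retain the activity of compound 1.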